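A few compounds are considered here, and "the series" means these few. Any claim that something is new, unique, unknown or untested is made for them only; others in the source may bear on it.

Measured so far in a functional assay on the whole organism with Rattus norvegicus as the target, with a stated time of 3 h, at a dose of 400 mg/kg; on this read-out lower numbers stand for a weaker effect and higher numbers for a stronger effect at the one dose given:
Compound 1, `CCc1nc2c3ccccc3oc2c2c1c(=O)oc1cc(C)ccc12`: 46.5%
Compound 2, `O=c1oc2cc(Cl)ccc2c2c1cnc1c3ccccc3oc12`: 29.4%

On this read-out compound 1 gives 46.5%, the higher of the two numbers. Its nearest neighbour, compound 2, gives 29.4%, a number lower by a gap beyond the usual scatter. Going by the values given here, the two structures differ in more than one place, so no single step between them can be read off; their values show only that compound 1 stands above compound 2 in this assay.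

The step that follows leads from compound 1 to compound 3 `CCc1nc2c3ccccc3oc2c2c1c(=O)oc1cc(OC)ccc12`, which is still to be measured in this assay. Compared with compound 1 the change is this: methoxy in place of methyl on an aromatic carbon

Among the compounds with values here, no measured pair shows what such a change does in this assay, so the expectation rests on compound 1 alone. The expected step is a number 3.5 percentage points lower from compound 1 to compound 3 (within the scatter), which is meant as no change beyond the scatter, in either direction. Compound 3 is therefore estimated at 43%, with a range from 22% to 62%.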

Compound 3, a percentage reported as inhibition, in the whole organism at one dose (the size of the read-out at that dose, not a potency): 67.2%
Estimate against measurement, compound 3: 24.2 percentage points below; the whole stated range lies below it.
By their numbers in this assay, from the lowest: compound 2; then compound 1; then compound 3.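

In this assay, going by these compounds alone, methoxy in place of methyl on an aromatic carbon gives a number 20.7 percentage points higher from compound 1 to compound 3 (beyond the scatter), the first change in a single place that can be read. Compound 1 and compound 2 differ in more than one place, whereas this pair shows that the read-out responds, beyond the usual scatter, to the group on this carbon of the six-membered aromatic ring of carbon only, meta to a fused ring and para to a fused ring, while the rest of the core of compound 1 stays the same. Nothing given here accounts for the rise, and this single pair sets no rule for the position or for the same change on another core.

The compounds shown leave open whether the higher number goes with the oxygen that methoxy brings or with its additional heavy atom, and a hydroxyl, an ethoxy or an amine on the same carbon would help to separate these readings. They also leave open whether the same exchange would give a step of similar size on a core without the ethyl group of compound 1.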